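Extending the alkynyl chain of compound 1: cytotoxicity outlook

The source may report more compounds than this note shows. Statements on the series, on what has been measured and on what is new or still open speak of the compounds shown alone.

Measured compounds:
compound 1, `CCCCC#Cc1cc2cn([C@@H]3O[C@H](CO)[C@@H](O)[C@H]3O)c(=O)nc2o1`: > 144000 nM
compound 2, `CCCCCCC#Cc1cc2cn([C@H]3C[C@H](O)[C@@H](CO)O3)c(=O)nc2o1`: >= 97000 nM
compound 3, `CCCCC#Cc1cc2cn([C@@H]3O[C@H](CO)[C@@H](O)[C@@H]3O)c(=O)nc2o1`: > 144000 nM

In a functional assay on HEL cells (Homo sapiens) for cytotoxicity (on this read-out lower numbers stand for higher toxicity in this test and higher numbers for lower toxicity in this test), compound 1 gives > 144000 nM, which is a limit of the assay and not a number. Compound 3 likewise gives > 144000 nM, again a limit. Compound 2 gives >= 97000 nM, also a limit. Compound 1 therefore stands nowhere in particular on the numbers shown: every value is a limit, and the limit of > 144000 nM in this assay, at which 2 of the 3 values shown sit, together with the limit of >= 97000 nM in this assay, at which 1 of the 3 values shown sits, leaves no measured toxicity in this set.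

For the measured compounds named here, the one step between measured compounds, a step that the two limits leave unreadable from compound 1 to compound 3, cannot be read because the fact that compounds 1 and 3 differ only in the configuration as drawn puts two limits side by side. Compound 4, `CCCCCCCCC#Cc1cc2cn([C@@H]3O[C@H](CO)[C@@H](O)[C@H]3O)c(=O)nc2o1`, differs from compound 1 by butyl in place of hydrogen on a saturated chain carbon, four bonds along the chain from a triple-bonded carbon. Going by the values given here, no measured step bears on a chain extension of this kind; the only related pair, compound 2 against compound 1, shows two limits and nothing more.

The expectation for compound 4 in this assay is accordingly a step from compound 1 to compound 4 of a number no higher from compound 1 to compound 4 (the limit leaves the size open), that is, no step beyond the scatter, with a high chance that only a limit is reported again. Compound 4 is estimated at 144000 nM, between 50000 nM and 300000 nM.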

Compound 4, minimum cytotoxic concentration: 49000 nM
The estimate for compound 4 lay 2.9-fold (0.47 log units) above the measured number, and the stated range ends above it.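

In this assay, for the compounds shown here, butyl in place of hydrogen on a saturated chain carbon, four bonds along the chain from a triple-bonded carbon, gives an at least 2.9-fold lower number from compound 1 to compound 4 (0.46 log units; beyond the scatter), so this change at this place brings the first actual number into the set, where the earlier compounds offered only limits. From the compounds shown here alone, compound 1 gives > 144000 nM, which is a limit of the assay, so the step has a smallest size but no upper end, and the true distance between the two compounds stays unknown. Nothing in the data shown accounts for the change.

Going by these compounds, the step between compound 1 and compound 3 cannot be read, so it remains open whether the configuration at the saturated ring carbon matters for toxicity in this test, or whether the same butyl change would have the same outcome on compound 3. Also open, on these data alone, is whether a longer chain than that of compound 4, or an amine in place of the butyl, would shift the number in this assay any further.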